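Aryl Exchange on the Ring Nitrogen of Compound 1

This account rests on a few compounds, and the source may have more. Where it says the series, first, only, none or still open, it means among the compounds named here.

Going by the values given here, compound 1 `CCC(C(=O)N1CCN(c2ccccc2F)CC1)N1C(=O)CCC1=O` gives 50% in a functional assay on the whole organism (strain Swiss) with Mus musculus as the target, in the maximal electroshock model, with a stated time of 1 h, at a dose of 300 mg/kg by the intraperitoneal route (a lower number here means a weaker effect, a higher number a stronger effect of the compound at the dose given), the higher of the two numbers measured so far. Compound 2 `CCC(C(=O)N1CCN(c2ccccc2C(F)(F)F)CC1)N1C(=O)CCC1=O` gives 0% in this assay, and the change of trifluoromethyl in place of fluoro on an aromatic carbon brings a number 50 percentage points lower from compound 1 to compound 2 (beyond the scatter). Compound 3 `CCC(C(=O)N1CCN(c2cccc(C)c2)CC1)N1C(=O)CCC1=O` differs from compound 1 by 3-methylphenyl in place of 2-fluorophenyl on an amine nitrogen in a ring. Among the compounds with values here, no measured step exchanges the whole aryl group in this way; the one step known shows only that a change on that aryl group can wipe out the effect. Compound 3 is therefore estimated at 25%, with an expected range from 0% to 65%. That estimate means an expected step of a number 25 percentage points lower from compound 1 to compound 3 (beyond the scatter).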

Compound 3, a percentage reported as activity, at one dose (the size of the read-out at that dose, not a potency): 75%
Compound 3: the middle estimate sits 50 percentage points below what was measured, and the stated range ends below it.
By their numbers in this assay, from the lowest: compound 2; then compound 1; then compound 3.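

In this assay the exchange of the aryl group gives a number 25 percentage points higher from compound 1 to compound 3 (beyond the scatter), so this place on the amine nitrogen in a ring can carry a group that raises the effect as well as one that removes it. Compound 3 carries no fluorine, so fluorine on the aryl group is not required for an effect here. Nothing measured here accounts for the rise.

The compounds shown do not separate the change from fluoro to methyl from the change of ring position in the names 2-fluorophenyl and 3-methylphenyl. Going by these compounds, how a methoxy group or a chlorine atom on the phenyl ring would fare also stays open.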